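Series notes: methyl on the aromatic nitrogen of compound 2

The source may hold more compounds than are shown below. What is called first, only, known or untested is meant among the compounds shown, and "the series" means these compounds.

Measured in a functional assay on A549 cells (Homo sapiens) for antiproliferative activity, read by MTT assay, with a stated time of 48 h; on this read-out higher numbers stand for weaker inhibition and lower numbers for stronger inhibition:
- compound 1 `CCOc1cc(-c2ccc3cc[nH]c3c2)cn2c(-c3cc(OC)c(OC)c(OC)c3)nnc12` gives 626 nM
- compound 2 `CCOc1cc(-c2ccc3[nH]ccc3c2)cn2c(-c3cc(OC)c(OC)c(OC)c3)nnc12` gives 589 nM
- compound 3 `COc1cc(-c2nnc3c(OC4CCC4)cc(-c4ccc5[nH]ccc5c4)cn23)cc(OC)c1OC` gives 232 nM

Compound 2, at 589 nM, sits with compound 1 at the upper end of the three numbers, the two being level within the scatter, while compound 3 lies clearly lower. The next step leads to compound 4 `CCOc1cc(-c2ccc3c(ccn3C)c2)cn2c(-c3cc(OC)c(OC)c(OC)c3)nnc12`, with methyl in place of hydrogen on an aromatic nitrogen, so that 1H-indol-5-yl becomes 1-methyl-1H-indol-5-yl: methyl in place of hydrogen on an aromatic nitrogen.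

Going by the values given here, no measured compound carries a group on that nitrogen, so no step measures this change directly. The nearest evidence is the change within the same group, 1H-indol-5-yl in place of 1H-indol-6-yl, which gives a 1.1-fold lower number from compound 1 to compound 2 (0.03 log units; within the scatter). The other step, cyclobutyl in place of ethyl on an oxygen on an aromatic ring, gives a 2.5-fold lower number from compound 2 to compound 3 (0.40 log units; beyond the scatter) and is only modest. Neither step sets a direction for the methyl change, so no shift beyond the scatter is expected in this assay. The expected change is a 1.2-fold lower number from compound 2 to compound 4 (0.09 log units; within the scatter). For compound 4 the estimated value is 480 nM, with an expected range from 160 nM to 1300 nM.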

Compound 4, half-maximal inhibitory concentration: 334 nM
Compound 4: middle estimate off by 1.4-fold (0.16 log units), on the high side; measured number inside the range.
By their numbers in this assay, from the lowest: compounds 3, 4, 2 and 1 (each within the scatter of the next, the first and the last beyond it).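

In this assay, going by these compounds alone, methyl in place of hydrogen on the aromatic nitrogen gives a 1.8-fold lower number from compound 2 to compound 4 (0.25 log units; within the scatter), which is the first direct reading of a change at this nitrogen and shows that, for this one small group, the number stays level with that of the parent. Measured against the 1H-indol-6-yl compound, the 1-methyl-1H-indol-5-yl group gives a 1.9-fold lower number from compound 1 to compound 4 (0.27 log units; within the scatter), so compounds 1, 2 and 4 form one level group in this assay, and the hydrogen on that nitrogen can give way to methyl without a shift beyond the scatter. The data offer no measurement that could explain this tolerance at the nitrogen.

The compounds shown leave open whether a group larger than methyl on that nitrogen, such as ethyl, benzyl or a chain ending in a carboxylic acid, would also stay level with compound 2. Also open, from the compounds shown here alone, is how methyl on this nitrogen reads when combined with the cyclobutyl on oxygen of compound 3, or when placed on the 1H-indol-6-yl group of compound 1.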